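Methyl on the saturated chain of compound 1

A few compounds are considered here, and "the series" means these few. Any claim that something is new, unique, unknown or untested is made for them only; others in the source may bear on it.

Measured so far in a physicochemical assay for solubility, with a stated time of 24 h, tested at 30 mg/mL (on this read-out higher numbers stand for higher solubility and lower numbers for lower solubility), for this series:
- compound 1 `O=C(CCCCCNc1c(Nc2ccccc2)c(=O)c1=O)NO` gives 2200000 nM
- compound 2 `Cc1cccc(Nc2c(NCCCCCC(=O)NO)c(=O)c2=O)c1` gives 11000000 nM

Compound 1 holds the lower of the two numbers. Compound 3 `CC(CCCCC(=O)NO)Nc1c(Nc2ccccc2)c(=O)c1=O` differs from compound 1 by methyl in place of hydrogen on a saturated chain carbon bound to a nitrogen on an aromatic ring and a saturated chain carbon and has not been measured. Among the compounds with values here, the only measured step is a 5.0-fold higher number from compound 1 to compound 2 (0.70 log units; beyond the scatter) and it is modest. That methyl sits on an aromatic carbon, so it bears only loosely here. A smaller upward step in this assay is therefore expected, perhaps none beyond the scatter. The expected outcome is a 1.8-fold higher number from compound 1 to compound 3 (0.26 log units; within the scatter) and this estimate is loose. For compound 3 the estimated value is 4000000 nM with an expected range from 1500000 nM to 12000000 nM as its upper end.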

Compound 3, solubility: 46000000 nM
Compound 3: middle estimate off by 12-fold (1.06 log units), on the low side, outside the stated range (above it).
By their numbers in this assay, from the lowest: compound 1; then compound 2; then compound 3.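

In this assay, methyl in place of hydrogen on a saturated chain carbon bound to a nitrogen on an aromatic ring and a saturated chain carbon gives a 21-fold higher number from compound 1 to compound 3 (1.32 log units; beyond the scatter), a large step. The same replacement on an aromatic carbon gives the modest 5.0-fold higher number from compound 1 to compound 2 (0.70 log units; beyond the scatter), so for these two changes to compound 1 the size of the step depends on where the methyl sits. No measurement here accounts for the difference between the two steps.

Going by these compounds, whether ethyl or hydroxymethyl at this chain carbon would give a step of similar size remains open. Also open, on these data alone, is how the chain methyl and the aromatic methyl behave together on the core of compound 1.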